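The source may hold more compounds than are shown below. What is called first, only, known or untested is meant among the compounds shown, and "the series" means these compounds.

Compound 1: `OC[C@H]1O[C@@H](n2cnc3c(NCc4ccccc4Cl)ncnc32)[C@H](O)[C@@H]1O` — in a functional assay on B16 cells (Mus musculus) for antiproliferative activity, with a stated time of 72 h (a lower number here means a stronger inhibitor, a higher number a weaker inhibitor), compound 1 gives only a limit, > 166000 nM.
Compound 2: `OC[C@H]1O[C@@H](n2cnc3c(NCc4ccc(Br)cc4)ncnc32)[C@H](O)[C@@H]1O` — in this assay compound 2 likewise gives only a limit, > 166000 nM.

Compound 1 stands at the limit of > 166000 nM in this assay, at which 2 of the 2 values shown sit, so no number is known for it, and the step that the two limits leave unreadable from compound 1 to compound 2 cannot be read. Compound 3 is `COc1cccc(CNc2ncnc3c2ncn3[C@@H]2O[C@H](CO)[C@@H](O)[C@H]2O)c1`; it differs from compound 1 by 3-methoxyphenyl in place of 2-chlorophenyl on a saturated chain carbon bound to a nitrogen on an aromatic ring. Within the data shown here, no measured step bears on this change, and both neighbours rest at the same limit. For compound 3 the estimated step that the limit leaves unreadable from compound 1 to compound 3 is therefore expected to be none beyond the scatter, with a limit again likely. Compound 3 is expected at 250000 nM, between 60000 nM and 1000000 nM.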

Compound 3, half-maximal inhibitory concentration: > 166000 nM
Compound 3 was reported as a limit; the forecaster's own chance of this, stated with the estimate: 85%; the middle value does not contradict the limit.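

Among these compounds, compound 3 also gives only a limit, so no step among compound 1, compound 2 and compound 3 can be read: the limit of > 166000 nM in this assay, at which 3 of the 3 values shown sit. As far as these compounds go, whether these three compounds differ at all in this assay stays open.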